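From Phenyl to 4-(Methylsulfanyl)phenyl in Compound 4

The source may report more compounds than this note shows. Statements on the series, on what has been measured and on what is new or still open speak of the compounds shown alone.

Compound 1 `O=C(CCc1cccc2c1B(O)OC2)NCc1ccccc1`: > 100000 nM
Compound 2 `C#Cc1ccccc1NC(=O)CCc1cccc2c1B(O)OC2`: 1400 nM
Compound 3 `O=C(CCc1cccc2c1B(O)OC2)Nc1cccc(-c2ccccc2)c1`: 890 nM

Three amides built on a shared core have been tested in a functional assay on HCT-116 cells (Homo sapiens) for antiproliferative activity, read by MTT assay, with a stated time of 72 h; on this read-out lower numbers stand for stronger inhibition and higher numbers for weaker inhibition. Compound 3 gives 890 nM, the lowest of the two numbers reported. Compound 2 gives 1400 nM, and this value sits within the scatter of that of compound 3, so no order between the two can be drawn. For compound 1 the result is a limit of the assay rather than a number, > 100000 nM. No pair among these three differs in a single place, so no measured step is available to calibrate what a small change does here.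

Compound 4 `CSc1ccc(-c2cccc(NC(=O)CCc3cccc4c3B(O)OC4)c2)cc1` has not yet been measured. It differs from compound 3 as follows: methylsulfanyl in place of hydrogen on an aromatic carbon. Within the data shown here, nothing among the measured compounds speaks to the effect of such a change, so the expectation rests on the change alone. Compound 4 is expected to give 700 nM, with a likely range from 250 nM to 2000 nM. The expected step of a 1.3-fold lower number from compound 3 to compound 4 (0.10 log units; within the scatter) is therefore small, not clearly beyond the scatter in either direction.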

Compound 4, half-maximal inhibitory concentration: 180 nM
Estimate against measurement, compound 4: 3.9-fold (0.59 log units) above; measured number below the stated range.
By their numbers in this assay, from the lowest: compound 4; then compounds 3 and 2 (each within the scatter of the next). At a limit, above all of these: compound 1.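

In this assay, methylsulfanyl in place of hydrogen on an aromatic carbon, para to a large group, gives a 4.9-fold lower number from compound 3 to compound 4 (0.69 log units; beyond the scatter). Among these compounds, this is the first step that can be read between two compounds differing in one place, and it shows that the phenyl of compound 3 is a site where a single substitution of just a sulfur and a carbon moves the read-out beyond the usual scatter, something the three earlier compounds, with no such pair among them, could not show. Why the number falls remains unexplained, as nothing measured here bears on the cause of this step.

The step is a single observation at a single position, so it does not tell whether the change depends on the sulfur, on the methyl, or on any substituent at that carbon, and a methoxy group, a chlorine atom, an amine or a carboxylic acid in the same place would begin to separate these readings. It also leaves open whether the same group would give a comparable step elsewhere on that ring, or on another amide built on the shared core.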